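Adding a Fluorine to the Styryl Ring of Compound 3

This account rests on a few compounds, and the source may have more. Where it says the series, first, only, none or still open, it means among the compounds named here.

Of the compounds shown here, three sharing one core have been tested in a functional assay on HeLa cells (Homo sapiens) for cytotoxicity, read by MTT assay, with a stated time of 2 days; on this read-out higher numbers stand for lower toxicity in this test and lower numbers for higher toxicity in this test. Compound 1, `CC(=O)c1cc(-c2ccccc2)cc2cc(-c3ccc(F)cc3)[nH]c12`, reaches only a limit there: compound 1 gives > 100000 nM, which is a limit of the measurement and not a number. Compound 2, `COc1ccc(-c2cc(C(C)=O)c3[nH]c(-c4ccc(F)cc4)cc3c2)cc1`, carries a methoxy group on its outer ring and gives 9460 nM. Compound 3, `CC(=O)c1cc(/C=C/c2ccccc2)cc2cc(-c3ccc(F)cc3)[nH]c12`, carries a 2-phenylethenyl group where compound 1 has phenyl. In this assay compound 3 gives 16100 nM. Of the two actual numbers, compound 3 has the higher one, with compound 2 nearest; the two sit within the scatter, as a 1.7-fold higher number from compound 2 to compound 3 (0.23 log units; within the scatter) shows. Against compound 1, both an at least 10-fold lower number from compound 1 to compound 2 (1.02 log units; beyond the scatter) and an at least 6.2-fold lower number from compound 1 to compound 3 (0.79 log units; beyond the scatter) lie beyond the scatter, although each starts from the limit of > 100000 nM in this assay, at which 1 of the 3 values shown sits, and so its true size is uncertain.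

Compound 4, `CC(=O)c1cc(/C=C/c2ccc(F)cc2)cc2cc(-c3ccc(F)cc3)[nH]c12`, differs from compound 3 only by fluoro in place of hydrogen on an aromatic carbon. For the measured compounds named here, no measured step adds a fluoro to this ring. Going by the values given here, the closest precedent is the addition of a methoxy group in an at least 10-fold lower number from compound 1 to compound 2 (1.02 log units; beyond the scatter), but that step begins at a limit and concerns a different group. A step no larger than the scatter is therefore expected: compound 4 is expected to show a 1.2-fold lower number from compound 3 to compound 4 (0.09 log units; within the scatter). For compound 4 the estimated value is 13000 nM, with a likely range from 5000 nM to 35000 nM.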

Compound 4, concentration lethal to 50% of the cells: 5680 nM
Beside the measured number, compound 4's estimate is 2.3-fold (0.36 log units) above it, and the stated range covers the measured number.
By their numbers in this assay, from the lowest: compounds 4, 2 and 3 (each within the scatter of the next, the first and the last beyond it). At a limit, above all of these: compound 1.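

In this assay, for the compounds shown here, the outer ring of the 2-phenylethenyl group proves sensitive to a very small change: a 2.8-fold lower number from compound 3 to compound 4 (0.45 log units; beyond the scatter), and this is the only step between two actual numbers that lies beyond the scatter. A single fluoro, para to a large group, is therefore enough to give a lower number and so higher toxicity in this test, although it does not separate the new compound from the methoxy compound, as a 1.7-fold lower number from compound 2 to compound 4 (0.22 log units; within the scatter) stays within the scatter. The remaining step, an at least 17-fold lower number from compound 1 to compound 4 (1.24 log units; beyond the scatter), is large, but its true size is uncertain because it starts from a limit: the limit of > 100000 nM in this assay, at which 1 of the 4 values shown sits.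

The compounds shown leave open whether fluoro is special at this place or whether a chloro, a methyl or an amine on the same ring would lower the number just as far. They also leave open whether a fluoro on the outer phenyl ring of compound 1, with no ethenyl link, would bring any measurable toxicity at all.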